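From trifluoromethyl to trifluoromethoxy in compound 3

A few compounds are considered here, and "the series" means these few. Any claim that something is new, unique, unknown or untested is made for them only; others in the source may bear on it.

In a functional assay on CWR22R cells (Homo sapiens) for antiproliferative activity, read by propidium iodide staining, with a stated time of 96 h (a lower number here means a stronger inhibitor, a higher number a weaker inhibitor), compound 1 (`CC(O)(COc1cccc(C(F)(F)F)c1)C(=O)Nc1cccc(S(F)(F)(F)(F)F)c1`) gives 28900 nM. Compound 2 (`CC(O)(CS(=O)(=O)c1ccccc1C(F)(F)F)C(=O)Nc1cccc(S(F)(F)(F)(F)F)c1`) gives 27700 nM in this assay, and these two numbers lie within the scatter of each other. Within the data shown here, compound 2 therefore has no separate rank on the numbers so far and stands level with compound 1. Among the measured compounds shown here, no measured pair differs in one place only, so no measured step is available as a guide to the next change.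

Compound 3 (`CC(O)(CS(=O)(=O)c1ccccc1OC(F)(F)F)C(=O)Nc1cccc(S(F)(F)(F)(F)F)c1`) carries trifluoromethoxy in place of trifluoromethyl on an aromatic carbon, ortho to a large group (trifluoromethoxy in place of trifluoromethyl on an aromatic carbon). For the measured compounds named here, the data hold no example of this change, so no step beyond the scatter is expected in this assay, and neither direction is favoured. This expectation rests only on compound 2 at 27700 nM. The expected change is a 1.1-fold lower number from compound 2 to compound 3 (0.03 log units; within the scatter), which stays within the scatter. For compound 3 the estimated value is 26000 nM, with an expected range of 12000 nM to 55000 nM.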

Compound 3, half-maximal inhibitory concentration: 17100 nM
Compound 3: the middle estimate sits 1.5-fold (0.18 log units) above what was measured; the range from low to high includes it.
By their numbers in this assay, from the lowest: compounds 3, 2 and 1 (each within the scatter of the next).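

In this assay the series now has its first step in one place, trifluoromethoxy in place of trifluoromethyl on an aromatic carbon, ortho to a large group, and it reads as a 1.6-fold lower number from compound 2 to compound 3 (0.21 log units; within the scatter). Compound 3 therefore has no separate rank from compound 2, so at this place the swap from trifluoromethyl to trifluoromethoxy, with one more heavy atom and one hydrogen-bond acceptor by count, brings no step beyond the scatter. This is a single reading at a single place, and it gives the position a first data point rather than a trend. No measured property bears on this result, so nothing here can account for it.

From the compounds shown here alone, it stays open whether this position responds to substitution at all in this assay, since two groups so alike in their counts give no wide test of it. A group of a different kind on the same aromatic carbon, such as an amine or a carboxylic acid, would show whether the numbers can move beyond the scatter from this place.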